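A fluorophenyl in place of cyclopentyl: expected inhibition

The source may hold more compounds than are shown below. What is called first, only, known or untested is meant among the compounds shown, and "the series" means these compounds.

Compound 1 `CC(C)c1sc(-c2ccccc2)c(C2CCCC2)c1/C=C/[C@@H](O)C[C@@H](O)CC(=O)O`: 417 nM
Compound 2 `CC(C)c1sc(-c2ccccc2)c(-c2ccccc2F)c1/C=C/[C@@H](O)C[C@@H](O)CC(=O)O`: 233 nM

In an assay on microsomes for inhibition of 3-hydroxy-3-methylglutaryl-coenzyme A reductase (Rattus norvegicus) (on this read-out lower numbers stand for stronger inhibition and higher numbers for weaker inhibition), compound 1 gives 417 nM and compound 2 gives 233 nM. Compound 1 stands at one end of these two numbers, but the step of a 1.8-fold lower number from compound 1 to compound 2 (0.25 log units; within the scatter) stays within the scatter. Compound 3 `CC(C)c1sc(-c2ccccc2)c(-c2cccc(F)c2)c1/C=C/[C@@H](O)C[C@@H](O)CC(=O)O` has not yet been measured; it differs from compound 1 by 3-fluorophenyl in place of cyclopentyl on an aromatic carbon. Within the data shown here, the one measured step that bears on it is a 1.8-fold lower number from compound 1 to compound 2 (0.25 log units; within the scatter), where a fluorophenyl also replaced cyclopentyl at the same position and the number barely moved. Compound 3 is therefore estimated at 270 nM, ranging from 110 nM to 650 nM, an expected step of a 1.5-fold lower number from compound 1 to compound 3 (0.19 log units; within the scatter) that should not exceed the scatter.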

Compound 3, half-maximal inhibitory concentration: 49 nM
Compound 3: the middle estimate sits 5.5-fold (0.74 log units) above what was measured, and the stated range ends above it.
By their numbers in this assay, from the lowest: compound 3; then compounds 2 and 1 (each within the scatter of the next).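

In this assay, this position proves sensitive to where the fluorine sits on the phenyl ring: 3-fluorophenyl in place of 2-fluorophenyl gives a 4.8-fold lower number from compound 2 to compound 3 (0.68 log units; beyond the scatter). Replacing cyclopentyl with 3-fluorophenyl gives an 8.5-fold lower number from compound 1 to compound 3 (0.93 log units; beyond the scatter), so a fluorophenyl in place of cyclopentyl can matter, although the 2-fluorophenyl swap stayed within the scatter. No measurement here explains the difference between the two fluorophenyl groups. Still open, as far as these compounds go, is how a plain phenyl group would compare with 3-fluorophenyl at this position. From the compounds shown here alone, a phenyl carrying chlorine or a methoxy group in place of the fluorine is equally open.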